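Aryl replacement at the ortho position of the benzylamide core

This account rests on a few compounds, and the source may have more. Where it says the series, first, only, none or still open, it means among the compounds named here.

Measured compounds in an assay on CHO cells for antagonist activity at transient receptor potential cation channel subfamily V member 1 (Homo sapiens), read by FLIPR; a lower number here means a stronger inhibitor, a higher number a weaker inhibitor:
compound 1 `CC(C(=O)NCc1ccc(C(F)(F)F)cc1N1CCN(C2CCCCC2)CC1)c1ccc(NS(C)(=O)=O)c(F)c1` gives 13.8 nM
compound 2 `CC(C(=O)NCc1ccc(C(F)(F)F)cc1OCc1ccc(F)cc1)c1ccc(NS(C)(=O)=O)c(F)c1` gives 0.5 nM
compound 3 `CC(C(=O)NCc1ccc(C(F)(F)F)cc1-c1ccc(C(C)(C)C)cc1)c1ccc(NS(C)(=O)=O)c(F)c1` gives 1.1 nM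

Compound 3 stands second highest of the three numbers. Its nearest neighbour is compound 2, a 2.2-fold higher number from compound 2 to compound 3 (0.34 log units; beyond the scatter); furthest away is compound 1, a 13-fold lower number from compound 1 to compound 3 (1.10 log units; beyond the scatter). All three compounds share the same core and differ only in the group attached at one aromatic carbon, so the whole spread so far comes from that position.

Compound 4 `CC(C(=O)NCc1ccc(C(F)(F)F)cc1-c1cccnc1)c1ccc(NS(C)(=O)=O)c(F)c1` is the next member. The change from compound 3 is pyridin-3-yl in place of 4-(tert-butyl)phenyl on an aromatic carbon; the new group sits ortho to a large group and meta to a trifluoromethyl group. For the measured compounds named here, two measured steps touch this position. Going by the values given here, the large step of a 13-fold lower number from compound 1 to compound 3 (1.10 log units; beyond the scatter) and the modest step of a 2.2-fold higher number from compound 2 to compound 3 (0.34 log units; beyond the scatter) show that the group here moves the number by a wide margin, but neither of them replaces a six-membered aromatic ring of carbon only with a ring bearing one hetero atom, so no step bears directly on the present change. The group entering is much smaller than the one leaving, and compound 2 shows a smaller neutral group is compatible with a low number.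

The expected step of a 4.5-fold higher number from compound 3 to compound 4 (0.66 log units; beyond the scatter) is a moderate increase; compound 4 is estimated at 5 nM with a range of 1.5 nM to 20 nM.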

Compound 4, inhibition constant: 59.4 nM
Compound 4: the middle estimate sits 12-fold (1.07 log units) below what was measured; measured number outside the range, above it.
By their numbers in this assay, from the lowest: compound 2; then compound 3; then compound 1; then compound 4.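

In this assay, pyridin-3-yl gives the highest number among the four groups at this aromatic carbon, with a 54-fold higher number from compound 3 to compound 4 (1.73 log units; beyond the scatter), a 120-fold higher number from compound 2 to compound 4 (2.07 log units; beyond the scatter) and a 4.3-fold higher number from compound 1 to compound 4 (0.63 log units; beyond the scatter). A six-membered aromatic ring joined directly to this carbon is therefore not enough for a low number: compound 3 and compound 4 both carry one, yet they lie far apart, and compound 4 also stands above compound 1, whose 4-cyclohexylpiperazin-1-yl group contains no aromatic ring. No measurement on hand accounts for this rise.

The change from compound 3 to compound 4 swaps a ring carbon for nitrogen and removes the tert-butyl group in one move, so the compounds shown cannot assign the rise to either part. A plain phenyl ring and a pyridin-3-yl ring bearing a tert-butyl group would separate the two, while a pyridin-4-yl ring or a phenyl ring bearing an amine would show whether the rise depends on where the nitrogen sits or extends to other nitrogen-containing groups.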